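From methoxy to fluoro in compound 3

This account rests on a few compounds, and the source may have more. Where it says the series, first, only, none or still open, it means among the compounds named here.

Compound 1 `CC(C)(C)c1ccc(-c2cn(CC3=C(Cl)c4ccc(-c5cccs5)nc4CC3)nn2)cc1` gives 172 ug/mL
Compound 2 `COc1ccc(-c2cn(CC3=C(Cl)c4ccc(-c5cccs5)nc4CC3)nn2)cc1` gives > 300 ug/mL (a limit of the assay)

In an ADME assay on MDCK cells (Canis lupus familiaris) for cytotoxicity, read by MTT assay, with a stated time of 48 h (on this read-out higher numbers stand for lower toxicity in this test and lower numbers for higher toxicity in this test), compound 2 has no number of its own, only a limit. Its standing is therefore open-ended, and it shares that position with nothing else measured so far (the limit of > 300 ug/mL in this assay, at which 1 of the 2 values shown sits). Compound 3 `Fc1ccc(-c2cn(CC3=C(Cl)c4ccc(-c5cccs5)nc4CC3)nn2)cc1` differs from it by one change on an aromatic carbon, para to a large group, with fluoro in place of methoxy (fluoro in place of methoxy on an aromatic carbon). Within the data shown here, only one measured step bears on this, a replacement on that same aromatic carbon (an at least 1.7-fold higher number from compound 1 to compound 2 (0.24 log units; that floor lies within the scatter)). With so little to go on, no step beyond the scatter and no clear direction is expected, and the expected step is small (an at least 1.0-fold lower number from compound 2 to compound 3 (0.02 log units; that floor lies within the scatter)). The estimated value for compound 3 is 280 ug/mL, with an expected range from 150 ug/mL to 500 ug/mL in this assay.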

Compound 3, half-maximal cytotoxic concentration: 100 ug/mL
Compound 3: middle estimate off by 2.8-fold (0.45 log units), on the high side; measured number below the stated range.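

In this assay, among these compounds, this position proves sensitive to the group it carries: fluoro in place of methoxy gives an at least 3.0-fold lower number from compound 2 to compound 3 (0.47 log units; beyond the scatter), the only step here that lies beyond the scatter. Fluoro and tert-butyl on this aromatic carbon, by contrast, cannot be told apart, with a 1.7-fold lower number from compound 1 to compound 3 (0.24 log units; within the scatter). From the compounds shown here alone, compound 2 gives > 300 ug/mL, which is a limit of the assay, so the full size of the step away from methoxy remains open-ended: the limit of > 300 ug/mL in this assay, at which 1 of the 3 values shown sits.

The compounds shown leave open whether the higher reading belongs to methoxy alone or would also come with an ethoxy or a hydroxyl group on the same aromatic carbon. They also do not tell how an amine or a carboxylic acid there would read, or whether the step from methoxy to fluoro would hold on a different core.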